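The source may report more compounds than this note shows. Statements on the series, on what has been measured and on what is new or still open speak of the compounds shown alone.

Working notes on the series. Among the compounds with values here, compound 1 `N/C(=N\O)c1ccc(C2=C(S(=O)(=O)c3ccc(/C(N)=N/O)cc3)CC(c3ccccc3)(c3ccccc3)O2)cc1` gives 119000 nM in an ADME assay on THP-1 cells (Homo sapiens) for cytotoxicity, read by flow cytometry, with a stated time of 72 h (a lower number here means a stronger inhibitor, a higher number a weaker inhibitor), the only numerical value seen so far in this set. Compound 2 `N/C(=N\O)c1ccc(C2=C(S(=O)(=O)c3ccc(Nc4cccc(/C(N)=N/O)c4)cc3)CC(c3ccccc3)(c3ccccc3)O2)cc1` returns only a limit in this assay, > 50000 nM. The step that the limit leaves unreadable from compound 1 to compound 2 therefore cannot be sized; its only bearing is the limit of > 50000 nM in this assay, at which 1 of the 2 values shown sits. Compound 3 `N/C(=N\O)c1ccc(S(=O)(=O)C2=C(c3ccc(Nc4ccccc4/C(N)=N/O)cc3)OC(c3ccccc3)(c3ccccc3)C2)cc1` differs from compound 1 in the same way as far as counting goes: a group of 11 heavy atoms (7 carbon, 3 nitrogen, 1 oxygen; one six-membered aromatic ring of carbon only) in place of a group of 4 heavy atoms (1 carbon, 2 nitrogen, 1 oxygen; no ring), on an aromatic carbon. No readable step bears on this change, so no direction beyond the scatter is expected. For compound 3 the estimate in this assay is 100000 nM (range 40000 nM to 250000 nM), meaning an expected step of a 1.2-fold lower number from compound 1 to compound 3 (0.08 log units; within the scatter).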

Compound 3, half-maximal inhibitory concentration: 47800 nM
Beside the measured number, compound 3's estimate is 2.1-fold (0.32 log units) above it, within the range that was stated.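

In this assay, within the data shown here, the group with one six-membered aromatic ring of carbon only, in place of the smaller group on this aromatic carbon, gives a 2.5-fold lower number from compound 1 to compound 3 (0.40 log units; beyond the scatter) as the first readable step for this change. Compound 2 holds only a limit, and its step from compound 1 cannot be read: the limit of > 50000 nM in this assay, at which 1 of the 3 values shown sits.

From the compounds shown here alone, whether a much smaller group on this aromatic carbon, such as an amine or a carboxylic acid, gives a step of similar direction stays open. So does whether the ring or the linking nitrogen carries the step.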